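The compounds below may be only part of what the source reports. "The series", "measured", "known", "first", "only" and "open" are said of these compounds alone.

Compounds measured in an in vitro assay on HEK385-7 cells for displacement of a labelled ligand from prostaglandin D2 receptor 2 (Homo sapiens); on this read-out lower numbers stand for stronger inhibition and higher numbers for weaker inhibition:

Compound 1, `O=C(O)Cc1sc(C(c2ccc(F)cc2)c2ccc(F)cc2)nc1-c1ccc(Cl)cc1`: 9.7 nM
Compound 2, `O=C(O)Cc1sc(C(c2ccccc2)c2ccccc2)nc1-c1ccc(F)cc1`: 8.7 nM

Within the data shown here, two compounds share the core and differ in more than one place, so no single step between them can be drawn. In this assay compound 2 gives 8.7 nM, the lowest of the two numbers measured, while compound 1 gives 9.7 nM, a gap that falls within the scatter, so the two values cannot be told apart.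

Compound 3, `O=C(O)Cc1sc(C(c2ccccc2)c2ccccc2)nc1-c1ccc(F)c(F)c1`, is not yet measured. It differs from compound 2 in one place: fluoro in place of hydrogen on an aromatic carbon. Among the measured compounds shown here, no pair of measured compounds shows what such a change does in this assay, so there is nothing here to lean on beyond the values of compound 2 and compound 1 themselves, which sit close together despite several differences in their aryl groups. On that basis the step is expected to be small, a 1.0-fold higher number from compound 2 to compound 3 (0.01 log units; within the scatter), in no particular direction and not beyond the scatter. Compound 3 is therefore estimated at 9 nM, with a range from 4 nM to 22 nM.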

Compound 3, half-maximal inhibitory concentration: 4.1 nM
Compound 3: the middle estimate sits 2.2-fold (0.34 log units) above what was measured; the measured number falls inside the stated range.
By their numbers in this assay, from the lowest: compound 3; then compounds 2 and 1 (each within the scatter of the next).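

In this assay, among these compounds, the change from 4-fluorophenyl to 3,4-difluorophenyl gives a 2.1-fold lower number from compound 2 to compound 3 (0.33 log units; beyond the scatter) and is the first single change here whose effect can be read. It shows that a fluoro group on this aromatic carbon, ortho to a fluoro group and meta to a large group, is accepted and moves the number beyond the scatter, though the step is modest and rests on this one pair, so it says nothing yet about the same change on any other compound. Nothing available accounts for the step, and its cause remains unknown.

Going by these compounds, whether chloro, methyl or methoxy on this same aromatic carbon would give a number like that of compound 3 stays open, as does whether an added fluoro group would act in the same way on the chlorine-bearing aryl group of compound 1. The compounds shown also leave open how the number responds when the acetic acid side chain or the two phenyl rings of the diphenylmethyl group are changed on this 3,4-difluorophenyl background.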